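From propanoyl to butylcarbonyl in a cytotoxic series

The source may hold more compounds than are shown below. What is called first, only, known or untested is meant among the compounds shown, and "the series" means these compounds.

Compound 1 `C=CCOc1cc(/C=C/C(=O)c2ccc(OC)c3c2OC(C)(C)C=C3)ccc1OC`: > 10000 nM, a limit of the assay
Compound 2 `COc1ccc(/C=C/C(=O)c2ccc(OC)c3c2OC(C)(C)C=C3)cc1OCCO`: 8750 nM
Compound 3 `CCC(=O)Oc1cc(/C=C/C(=O)c2ccc(OC)c3c2OC(C)(C)C=C3)ccc1OC`: 160 nM

In a functional assay on K562 cells (Homo sapiens) for cytotoxicity, read by MTT assay (on this read-out lower numbers stand for stronger inhibition and higher numbers for weaker inhibition), compound 3 stands lowest at 160 nM, and it is the most potent of the three measured compounds. Its nearest numerical neighbour is compound 2, and the gap is a 55-fold lower number from compound 2 to compound 3 (1.74 log units; beyond the scatter). The value of compound 1 is only a limit. The step to compound 3 can therefore be given only as an at least 62-fold lower number from compound 1 to compound 3 (1.79 log units; beyond the scatter). By contrast, an at least 1.1-fold lower number from compound 1 to compound 2 (0.05 log units; that floor lies within the scatter).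

Compound 4 `CCCCC(=O)Oc1cc(/C=C/C(=O)c2ccc(OC)c3c2OC(C)(C)C=C3)ccc1OC` changes compound 3 in one place: ethyl in place of hydrogen on a saturated chain carbon, two bonds along the chain from a carbonyl carbon. The same difference reads propanoyl to butylcarbonyl. Going by the values given here, no measured step varies the length of this chain, so the data give no direct size for the change. Both large steps replace a group on the oxygen on the aromatic ring with propanoyl. Compound 4 keeps a carbonyl at that oxygen, so a return to the level of compound 2 at 8750 nM is not expected. A small rise, possibly within the scatter, is the expected outcome. The estimate means an expected 1.6-fold higher number from compound 3 to compound 4 (0.19 log units; within the scatter). Compound 4 is expected at 250 nM, with an estimated range of 70 nM to 1200 nM.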

Compound 4, half-maximal inhibitory concentration: 240 nM
Compound 4: the middle estimate sits 1.0-fold (0.02 log units) above what was measured, within the range that was stated.
By their numbers in this assay, from the lowest: compounds 3 and 4 (each within the scatter of the next); then compound 2. At a limit, above all of these: compound 1.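

In this assay, going by these compounds alone, the first change to the chain itself, from propanoyl to butylcarbonyl, gives a 1.5-fold higher number from compound 3 to compound 4 (0.18 log units; within the scatter), so compound 3 and compound 4 cannot be told apart and this chain carbon, two bonds along the chain from a carbonyl carbon, accepts an ethyl in place of hydrogen. The large gaps seen with propanoyl on the oxygen on the aromatic ring also hold with butylcarbonyl, with a 36-fold lower number from compound 2 to compound 4 (1.56 log units; beyond the scatter) when it replaces 2-hydroxyethyl and an at least 41-fold lower number from compound 1 to compound 4 (1.61 log units; beyond the scatter) when it replaces allyl. Compound 1 stands at a limit, so the second of these gaps gives only a floor: the limit of > 10000 nM in this assay, at which 1 of the 4 values shown sits.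

As far as these compounds go, how far this tolerance extends stays open, as two chain lengths on the carbonyl say nothing about a much longer chain such as decanoyl or a ring-bearing group such as benzoyl. Whether the carbonyl itself accounts for the large gaps also remains unsettled, and a plain butyl or propyl group on the same oxygen, or a carbamate carrying an amine nitrogen there, would bear on that question.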